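From compound 1 to compound 3: a second chloro

A few compounds are considered here, and "the series" means these few. Any claim that something is new, unique, unknown or untested is made for them only; others in the source may bear on it.

Measured in an ADME assay on MDBK cells (Bos taurus) for cytotoxicity, read by MTT assay, with a stated time of 96 h; on this read-out higher numbers stand for lower toxicity in this test and lower numbers for higher toxicity in this test:
- compound 1 `Clc1cccc(/N=N/N2CCCC2)c1`: > 100000 nM
- compound 2 `O=[N+]([O-])c1cccc(/N=N/N2CCCC2)c1`: > 100000 nM

In this assay compound 1 stands at > 100000 nM, which is a limit and not a number. Compound 2 gives > 100000 nM, also a limit. Compound 3 `Clc1ccc(/N=N/N2CCCC2)cc1Cl` differs from compound 1 by chloro in place of hydrogen on an aromatic carbon. Within the data shown here, the only measured step is a step that the two limits leave unreadable from compound 1 to compound 2, and it involves a different change, so it offers no size to carry over. Among the measured compounds shown here, the sole guide is the limit of > 100000 nM in this assay, at which 2 of the 2 values shown sit, which points to a value near that limit, with at most a modest move towards lower numbers expected. The expected step is an at least 1.2-fold lower number from compound 1 to compound 3 (0.09 log units; that floor lies within the scatter). For compound 3 the estimated value is 80000 nM, within an expected range of 30000 nM to 100000 nM.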

Compound 3, half-maximal cytotoxic concentration: 70000 nM
Compound 3: the middle estimate sits 1.1-fold (0.06 log units) above what was measured; the range from low to high includes it.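

In this assay, among these compounds, compound 3 gives 70000 nM, the only value shown that is a number and not a limit, so a change at this position can be sized for the first time. Chloro in place of hydrogen, ortho to a chloro group and para to a group of 7 heavy atoms, gives an at least 1.4-fold lower number from compound 1 to compound 3 (0.15 log units; that floor lies within the scatter). The second chloro is therefore not shown to raise toxicity in this test, and most of the series remains unresolved: the limit of > 100000 nM in this assay, at which 2 of the 3 values shown sit.

Open, going by these compounds, is whether an amine or a methoxy group at this same position would give a step beyond the scatter.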